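Swapping the Amide Substituent on a Quinoline Acid Series

The source may report more compounds than this note shows. Statements on the series, on what has been measured and on what is new or still open speak of the compounds shown alone.

Of the compounds shown here, three sharing one core have been measured in a physicochemical assay for lipophilicity, using the shake flask method, in phosphate buffer, measured as octanol-water partition, at pH 7.4; a lower number here means a more polar compound, a higher number a more lipophilic compound. Compound 1 `COc1cc(-c2cc(C(=O)O)c3ccccc3n2)ccc1OCC(=O)Nc1cccc(C)c1` gives 1.5. Compound 2 `COc1cc(-c2cc(C(=O)O)c3ccccc3n2)ccc1OCC(=O)Nc1ccccc1Cl` gives 1.6, the highest of the three numbers, though it sits a number 0.10 log units higher from compound 1 to compound 2 (within the scatter), which separates it from compound 1 by nothing meaningful. Compound 3 `COc1cc(-c2cc(C(=O)O)c3ccccc3n2)ccc1OCC(=O)NCc1cccnc1`, which carries a (pyridin-3-yl)methyl group on the amide-type nitrogen instead of an aromatic ring attached directly, gives -0.8, a number a number 2.40 log units lower from compound 2 to compound 3 (beyond the scatter) and a number 2.30 log units lower from compound 1 to compound 3 (beyond the scatter).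

The next compound, compound 4 `COc1cc(-c2cc(C(=O)O)c3ccccc3n2)ccc1OCC(=O)NCc1cccs1`, differs from compound 2 at the same position: (thiophen-2-yl)methyl in place of 2-chlorophenyl on an amide-type nitrogen.

Going by the values given here, two measured steps bear on this. The step from compound 1 to compound 2, swapping one six-membered carbon ring for another, stayed within the scatter. The step from compound 2 to compound 3, which introduced a methylene-linked ring with one hetero atom and one hydrogen-bond acceptor, was large and downward. Compound 4 also brings a methylene-linked ring with one hetero atom, but a five-membered one with sulfur rather than a pyridine, so a downward step is expected, though a smaller one than a number 2.40 log units lower from compound 2 to compound 3 (beyond the scatter). For compound 4 the estimate in this assay is 0.8, between 0.1 and 1.5, corresponding to an expected step of a number 0.80 log units lower from compound 2 to compound 4 (beyond the scatter).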

Compound 4, distribution coefficient: 0
The estimate for compound 4 lay 0.80 log units above the measured number; measured number below the stated range.
By their numbers in this assay, from the lowest: compound 3; then compound 4; then compounds 1 and 2 (each within the scatter of the next).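

Measured in this assay, the (thiophen-2-yl)methyl group gives a number 1.60 log units lower from compound 2 to compound 4 (beyond the scatter) and a number 1.50 log units lower from compound 1 to compound 4 (beyond the scatter), yet also a number 0.80 log units higher from compound 3 to compound 4 (beyond the scatter). A methylene-linked ring on the amide-type nitrogen therefore does not fix the number by itself: compounds 3 and 4 both lie well under compounds 1 and 2, but they also stand apart from each other, so the ring on that saturated chain carbon matters too, with thiophen-2-yl and pyridin-3-yl giving clearly different results. Nothing available alongside these numbers accounts for the size of any of these steps.

Among the compounds shown, no two carry the same ring both with and without the methylene link, so the share of the drop that belongs to the link and the share that belongs to the change of ring stay open. A phenylmethyl group on the amide-type nitrogen would set a carbon-only ring on that same link, and a 2-(thiophen-2-yl)ethyl group, with its longer chain, would show how the number follows the length of the link.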